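Side-chain step from compound 1 to compound 4

A few compounds are considered here, and "the series" means these few. Any claim that something is new, unique, unknown or untested is made for them only; others in the source may bear on it.

Measured in a physicochemical assay for solubility; on this read-out lower numbers stand for lower solubility and higher numbers for higher solubility:
- compound 1 `C[C@H](N)C(=O)N[C@@H]1CN(c2nc3c(cc2F)c(=O)c(C(=O)O)cn3C2CC2)[C@H]1C`: > 500 ug/mL (a limit)
- compound 2 `C[C@H](N)C(=O)N[C@@H](C)C(=O)N[C@@H]1CN(c2nc3c(cc2F)c(=O)c(C(=O)O)cn3C2CC2)[C@H]1C`: > 500 ug/mL (a limit)
- compound 3 `C[C@@H](N)C(=O)N[C@@H]1CN(c2nc3c(cc2F)c(=O)c(C(=O)O)cn3C2CC2)[C@H]1C`: 495 ug/mL

Compound 1 stands at > 500 ug/mL, which is a limit and not a number. Compound 1 and compound 2 both rest on (the limit of > 500 ug/mL in this assay, at which 2 of the 3 values shown sit), so the series offers little room for reading steps.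

Compound 4 `CC(C)C[C@H](N)C(=O)N[C@@H]1CN(c2nc3c(cc2F)c(=O)c(C(=O)O)cn3C2CC2)[C@H]1C` carries the shared core of compound 1 and changes only in the terminal amino acid unit: isopropyl in place of hydrogen on a saturated chain carbon, two bonds along the chain from an amine nitrogen and a carbonyl carbon. The same difference reads methyl to isobutyl.

No measured step sizes this change. The nearest evidence is a number no higher from compound 1 to compound 3 (the limit leaves the size open), where the structural content is the fact that compounds 1 and 3 differ only in the configuration as drawn. The other two steps are a step that the two limits leave unreadable from compound 1 to compound 2 and a number no higher from compound 2 to compound 3 (the limit leaves the size open), and neither gives a usable size. Among the measured compounds shown here, with compound 3 at 495 ug/mL as the only readable number, the expectation stays in the same upper region of this assay, with a moderate downward step expected. The expected step is an at least 1.6-fold lower number from compound 1 to compound 4 (0.22 log units; that floor lies within the scatter), and a result at the limit would not be surprising. Compound 4 is estimated at 300 ug/mL, with an expected range of 110 ug/mL to 800 ug/mL.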

Compound 4, solubility: > 500 ug/mL
Compound 4: a limit, no number; the forecaster's own chance of this, stated with the estimate: 35%; middle value at least 1.6-fold (0.22 log units) from the limit.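

In this assay compound 4 gives > 500 ug/mL, which is a limit and not a number. Among the compounds shown here, with isobutyl in place of methyl on the terminal amino acid unit, the side chain at this saturated chain carbon now extends beyond anything the earlier compounds carried, and the reading still does not come off the limit; against the only number, the record is a number no lower from compound 3 to compound 4 (the limit leaves the size open). The steps that join compound 4 to compound 1 and to compound 2 cannot be read, and the series stays short of sized steps because so many of its readings end at the same ceiling: the limit of > 500 ug/mL in this assay, at which 3 of the 4 values shown sit.

The compounds shown leave open how far compound 1, compound 2 and compound 4 lie apart, and whether the configuration change that separates compound 1 from compound 3 would read the same with isobutyl in place of methyl. They also leave open whether a benzyl group, a carboxylic acid or a longer chain on the same saturated chain carbon would give a number rather than a limit in this assay.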